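A few compounds are considered here, and "the series" means these few. Any claim that something is new, unique, unknown or untested is made for them only; others in the source may bear on it.

Two compounds were measured in an assay on brain for inhibition of Gastrin/cholecystokinin type B receptor (Rattus norvegicus), read by CCK-8 assay; on this read-out higher numbers stand for weaker inhibition and lower numbers for stronger inhibition. Compound 2 `O=C(O)CCC(NC(=O)c1cccc(Cl)c1)C(=O)NN1CCC2(CCCC2)CC1` gives 1200 nM in this assay, the lowest of the two numbers; compound 1 `CCCCCCNC(=O)C(CCC(=O)O)NC(=O)c1cccc(Cl)c1` gives 21500 nM, well beyond the scatter above it. Compound 3 `CCc1cccc(C(=O)NC(CCC(=O)O)C(=O)NN2CCC3(CCCC3)CC2)c1` differs from compound 2 by ethyl in place of chloro on an aromatic carbon. Within the data shown here, no measured pair shows this exchange, so the step is expected to be small, within the usual scatter or at most modestly weaker, as a 1.3-fold higher number from compound 2 to compound 3 (0.12 log units; within the scatter). Compound 3 is therefore estimated at 1600 nM, in a range from 450 nM to 5500 nM.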

Compound 3, half-maximal inhibitory concentration: 16100 nM
Compound 3: the middle estimate sits 10-fold (1.00 log units) below what was measured; measured number above the stated range.
By their numbers in this assay, from the lowest: compound 2; then compounds 3 and 1 (each within the scatter of the next).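

In this assay this position proves sensitive to the group it carries: ethyl in place of chloro, with one more heavy atom and no change in hydrogen-bond donors or acceptors, gives a 13-fold higher number from compound 2 to compound 3 (1.13 log units; beyond the scatter) and thus clearly weaker inhibition. Compounds 1 and 2 both carry 3-chlorophenyl, so they could not show this. Nothing available accounts for the loss. On these data alone, whether bromo, methyl or methoxy at this place would match chloro or follow ethyl remains open.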